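The source may hold more compounds than are shown below. What is called first, only, known or untested is meant among the compounds shown, and "the series" means these compounds.

Measured compounds in an ADME assay on HFF cells (Homo sapiens) for cytotoxicity, read by MTT assay, with a stated time of 72 h; on this read-out lower numbers stand for stronger inhibition and higher numbers for weaker inhibition:
compound 1, `O=C1O/C(=C\Cn2cc(-c3ccc(Br)cc3)nn2)C(OCc2ccccc2)=C1OCc1ccccc1`, gives > 100000 nM, a limit of the assay.
compound 2, `O=C1O[C@H]([C@@H](O)Cn2cc(-c3ccc(Br)cc3)nn2)C(OCc2ccccc2)=C1OCc1ccccc1`, gives 5100 nM.
compound 3, `O=C1O/C(=C\Cn2cc(-c3cc(F)cc(F)c3)nn2)C(OCc2ccccc2)=C1OCc1ccccc1`, gives > 100000 nM, a limit of the assay.

Within the data shown here, compound 2 therefore stands as the only compound of the three with a number in this assay; the other two values are limits, as the limit of > 100000 nM in this assay, at which 2 of the 3 values shown sit, records. Among the measured compounds shown here, the one step computed between measured compounds, a step that the two limits leave unreadable from compound 1 to compound 3, is unreadable, since both ends sit at a limit, and no step to compound 2 is computed at all.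

Compound 4, `CCCCc1cn(C[C@H](O)[C@H]2OC(=O)C(OCc3ccccc3)=C2OCc2ccccc2)nn1`, is the compound yet to be measured. It differs from compound 2 in one place: butyl in place of 4-bromophenyl on an aromatic carbon. For the measured compounds named here, no measured step concerns this change, and the only readable value in this assay is that of compound 2. The expectation for compound 4 can thus rest only on the value of compound 2, 5100 nM, with no direction indicated beyond the scatter; the step of a 2.0-fold higher number from compound 2 to compound 4 (0.29 log units; within the scatter) is accordingly expected to be small, and the range is set wide. Compound 4 is estimated at 10000 nM, between 3000 nM and 60000 nM, with a real chance that only a limit is reported.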

Compound 4, half-maximal inhibitory concentration: 26300 nM
Compound 4: middle estimate off by 2.6-fold (0.42 log units), on the low side; the range from low to high includes it.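

Among these compounds, at the position on the five-membered aromatic ring with 3 nitrogen, the result gives the first readable step in this assay: butyl in place of 4-bromophenyl produces a 5.2-fold higher number from compound 2 to compound 4 (0.71 log units; beyond the scatter). With the rest of the molecule unchanged, this shows that the group at this position alone moves the read-out beyond the scatter, and that the higher number goes with the group that has no ring and no bromine, in this one pair. The value of compound 4 is also a number rather than a limit, so a group without a ring at this position still leaves the compound within the readable range, and the limit on record is unchanged: the limit of > 100000 nM in this assay, at which 2 of the 4 values shown sit.

The step between compound 1 and compound 3 cannot be read, since both of their values are limits, so nothing shows how a change at this position behaves in compounds with the unsaturated link of compound 1. A single pair also cannot separate the loss of the ring from the loss of the bromine, and a plain phenyl or a longer chain such as octyl at this position would bear on that question.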